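This account rests on a few compounds, and the source may have more. Where it says the series, first, only, none or still open, it means among the compounds named here.

In a physicochemical assay for lipophilicity, at pH 7.4 (on this read-out higher numbers stand for higher lipophilicity and lower numbers for lower lipophilicity), compound 1 `Cc1cc(N[C@H](CCCCNCc2ccccc2F)C(=O)NO)cc(C)c1F` gives < 3, which is a limit and not a number. Compound 2 `Cc1cc(N[C@H](CCCCNCc2ccc([N+](=O)[O-])cc2)C(=O)NO)cc(C)c1F` gives < 3, also a limit. Compound 3 `Cc1cc(N[C@H](CCCCNCc2ccc(C(C)(C)C)cc2)C(=O)NO)cc(C)c1F` gives < 3, again a limit. Compound 4 `Cc1cc(N[C@H](CCCCNCCCc2ccc(F)cc2)C(=O)NO)cc(C)c1F` differs from compound 1 in one place, on a saturated chain carbon bound to an amine nitrogen: 2-(4-fluorophenyl)ethyl in place of 2-fluorophenyl on a saturated chain carbon bound to an amine nitrogen. Two measured steps also change this group, a step that the two limits leave unreadable from compound 1 to compound 2 and a step that the two limits leave unreadable from compound 1 to compound 3, but neither has a readable size, as both ends of each are limits. They therefore support no expected direction, and no expected change beyond the scatter. The expected step, a step that the limit leaves unreadable from compound 1 to compound 4, is only a rough estimate. Compound 4 is expected to give about 2.4, with an estimated range from 1.7 to 3.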

Compound 4, distribution coefficient: < 3
Compound 4: only a limit was reported; the forecaster's own chance of this, stated with the estimate: 75%; the middle value lies beyond the limit too.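

Compound 4 gives < 3, which is a limit and not a number. Its steps from compound 1, compound 2 and compound 3 cannot be read. The compounds shown leave open where each truly lies in this assay, and whether changing this group shifts the read-out at all.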